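The source may hold more compounds than are shown below. What is called first, only, known or untested is meant among the compounds shown, and "the series" means these compounds.

The measured compounds:
compound 1, `CSc1ccc(C)cc1NCC1=NCCN1`: 0.912 nM
compound 2, `CSc1c(F)cccc1NCC1=NCCN1`: 33.9 nM

Compound 2 holds the highest number of the two in a functional assay for agonist activity at Alpha-1D adrenergic receptor (Homo sapiens); a higher number here means that more compound is needed for the effect, a lower number that less compound is needed; its nearest neighbour is compound 1, whose number is lower by a gap that lies beyond the scatter. The two compounds differ in more than one place, so the gap between them shows only what the two values show and cannot be traced to a single change.

Compound 3, `CS(=O)(=O)c1c(F)cccc1NCC1=NCCN1`, has not yet been measured. It differs from compound 2 in one place: methylsulfonyl in place of methylsulfanyl on an aromatic carbon. For the measured compounds named here, no step between measured compounds tells what this change does in this assay, and neither measured compound carries a methylsulfonyl group. Going by the values given here, with no step of this kind to go by, the size of the step is only an estimate; a moderate rise in the number, beyond the scatter, is expected, a 3.2-fold higher number from compound 2 to compound 3 (0.51 log units; beyond the scatter). For compound 3 the estimated value in this assay is 110 nM, within a range from 20 nM to 600 nM.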

Compound 3, half-maximal effective concentration: < 100000 nM
Compound 3 was reported as a limit; the forecaster's own chance of this, stated with the estimate: 10%; the middle value is on the limit's open side.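

In this assay compound 3 was reported only as a limit, < 100000 nM. No size can be read for the step from compound 2 to compound 3. The compounds shown leave open what methylsulfonyl in place of methylsulfanyl on an aromatic carbon does in this assay, including whether the number rises or falls.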